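Shortening the Chain on the Aromatic Nitrogen

A few compounds are considered here, and "the series" means these few. Any claim that something is new, unique, unknown or untested is made for them only; others in the source may bear on it.

Going by the values given here, compound 2 `CCCCCn1c(SCc2cc([N+](=O)[O-])ccc2OC)nc2cc(NC(=O)NC(C)(C)C)ccc21` stands as the weaker of the two compounds measured so far in an assay on isolated protein for inhibition of Gonadotropin-releasing hormone receptor (Homo sapiens); a lower number here means a stronger inhibitor, a higher number a weaker inhibitor: compound 2 gives 210 nM, while compound 1 `CCCn1c(SCc2cc([N+](=O)[O-])ccc2OC)nc2cc(NC(=O)NC(C)(C)C)ccc21` gives 18 nM. Among the compounds with values here, the single measured step, a 12-fold higher number from compound 1 to compound 2 (1.07 log units; beyond the scatter), separates them, and the change behind it is an ethyl in place of hydrogen on a saturated chain carbon, three bonds along the chain from an aromatic nitrogen. Compound 3 `COCCn1c(SCc2cc([N+](=O)[O-])ccc2OC)nc2cc(NC(=O)NC(C)(C)C)ccc21` has not yet been measured. It differs from compound 2 by methoxy in place of propyl on a saturated chain carbon, two bonds along the chain from an aromatic nitrogen; cut one bond further out, the same change reads pentyl to 2-methoxyethyl. Within the data shown here, only one measured step bears on this, and because a 12-fold higher number from compound 1 to compound 2 (1.07 log units; beyond the scatter) accompanied a longer chain on the aromatic nitrogen, returning to a shorter chain in compound 3 is expected to bring the number back down, although the methoxy that enters has no measured precedent here. Compound 3 is therefore expected to move most of the way back toward compound 1, a 5.3-fold lower number from compound 2 to compound 3 (0.72 log units; beyond the scatter). The estimate for compound 3 in this assay is 40 nM, with a range from 12 nM to 130 nM.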

Compound 3, half-maximal inhibitory concentration: 57 nM
The estimate for compound 3 lay 1.4-fold (0.15 log units) below the measured number; measured number inside the range.
By their numbers in this assay, from the lowest: compound 1; then compound 3; then compound 2.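

In this assay, methoxy in place of propyl, on a saturated chain carbon two bonds along the chain from an aromatic nitrogen, gives a 3.7-fold lower number from compound 2 to compound 3 (0.57 log units; beyond the scatter) and thus recovers part of what the pentyl chain gave up, so this position does not reject every chain that reaches beyond the propyl of compound 1. Methoxy in place of methyl at the same place gives a 3.2-fold higher number from compound 1 to compound 3 (0.50 log units; beyond the scatter) and shows for the first time that the position responds to what the chain carries as well as to its length, with compound 1 still ahead of compound 3 by more than the scatter. Nothing at hand accounts for either step.

The three compounds do not settle whether a butyl or an ethyl chain on the aromatic nitrogen would follow the trend from propyl to pentyl, or whether the drop with length is gradual or abrupt. They also leave open how a hydroxyl, an amine or a carboxylic acid would compare with the methoxy on this chain, and whether an ethoxy would behave as the methoxy does.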